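A few compounds are considered here, and "the series" means these few. Any claim that something is new, unique, unknown or untested is made for them only; others in the source may bear on it.

Compound 1 `CC1=CC[C@H](C(C)(C)NC(=S)N/N=C/c2ccccc2)CC1`: 8400 nM
Compound 2 `CC1=CC[C@H](C(C)(C)NC(=S)N/N=C/c2ccc(F)cc2)CC1`: > 100000 nM

Both compounds share one core and differ only in the ring attached to the carbon that carries a double bond to nitrogen. In a functional assay on MCF7 cells (Homo sapiens) for inhibition, read by sulforhodamine B assay, with a stated time of 48 h (a lower number here means a stronger inhibitor of growth, a higher number a weaker inhibitor of growth), compound 1 gives 8400 nM. Compound 2 reaches only > 100000 nM in this assay, which is a limit of the assay rather than a measured number, as stated by the limit of > 100000 nM in this assay, at which 1 of the 2 values shown sits. The step of an at least 11-fold higher number from compound 1 to compound 2 (1.07 log units; beyond the scatter) is therefore known only as a bound. Compound 3 `CC1=CC[C@H](C(C)(C)NC(=S)N/N=C/c2cccs2)CC1` changes the same place once more: thiophen-2-yl in place of 4-fluorophenyl on a carbon with a double bond to nitrogen. Among the compounds with values here, the one measured step that bears on this change is the step from compound 1 to compound 2, which was large; the change to compound 3 removes the fluorine again but brings in a ring not yet tested here, so the expectation stays wide. Compound 3 is expected to give 25000 nM, within 6000 nM to 100000 nM, which would mean an at least 4.0-fold lower number from compound 2 to compound 3 (0.60 log units; beyond the scatter).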

Compound 3, concentration for 50% growth inhibition: 4800 nM
Estimate against measurement, compound 3: 5.2-fold (0.72 log units) above; the whole stated range lies above it.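

In this assay, putting thiophen-2-yl in place of 4-fluorophenyl gives an at least 20-fold lower number from compound 2 to compound 3 (1.31 log units; beyond the scatter), so the loss of growth inhibition seen with 4-fluorophenyl does not extend to every change at this carbon. Thiophen-2-yl in place of phenyl gives a 1.8-fold lower number from compound 1 to compound 3 (0.24 log units; within the scatter), so a five-membered aromatic ring with one hetero atom and the plain six-membered ring cannot be told apart here. The first of these steps remains a bound, since the value for compound 2 is a limit of the assay and not a measured number: the limit of > 100000 nM in this assay, at which 1 of the 3 values shown sits.

The compounds shown leave open whether the loss belongs to fluorine alone or would also follow from a chlorine, a methoxy group or an amine on the phenyl ring. They also leave open what a carboxylic acid or a longer chain would do at this carbon in place of the ring.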